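Carboxy to 2H-tetrazol-5-yl at the assay limit

A few compounds are considered here, and "the series" means these few. Any claim that something is new, unique, unknown or untested is made for them only; others in the source may bear on it.

Four amides built on two related cores are compared in an assay on HEK293 cells for inhibition of Ataxin-2 (Mus musculus), read by fluorescence and Amplex Red; on this read-out higher numbers stand for weaker inhibition and lower numbers for stronger inhibition. Compound 1 `O=C(O)c1ccc(COc2ccc(CNC(=O)[C@@H]3CCC(=O)N3Cc3ccc(F)cc3)cc2)cc1` carries a carboxy group on its outer aromatic ring. In this assay compound 1 gives > 5000 nM, which is a limit of the assay and not a number. Compound 2 `O=C(NCc1ccc(OCc2ccc(-c3nn[nH]n3)cc2)cc1)[C@@H]1CCC(=O)N1Cc1ccc(F)cc1` is the matched analogue with 2H-tetrazol-5-yl in place of carboxy on an aromatic carbon. In this assay compound 2 gives > 5000 nM, again a limit of the assay rather than a number. The measured step that the two limits leave unreadable from compound 1 to compound 2 is therefore unreadable, because of the limit of > 5000 nM in this assay, at which 3 of the 3 values shown sit.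

Compound 3 `O=C(O)c1ccc(COc2ccc(CNC(=O)[C@@H]3CCCN3Cc3ccccc3)cc2)cc1` rests on the second core; the difference between the two cores is not broken down here. In this assay compound 3 gives > 5000 nM, a limit of the assay. Compound 4 `O=C(NCc1ccc(OCc2ccc(-c3nn[nH]n3)cc2)cc1)[C@@H]1CCCN1Cc1ccccc1` has not yet been measured. It differs from compound 3 by 2H-tetrazol-5-yl in place of carboxy on an aromatic carbon, the same change as that from compound 1 to compound 2, made at the same kind of place.

Nothing among the three measured compounds separates one from another, since all three sit at the same limit. For compound 4 the change from compound 3 is the one whose size could not be read between compound 1 and compound 2. In this assay the expected step is a step that the limit leaves unreadable from compound 3 to compound 4, because of the limit of > 5000 nM in this assay, at which 3 of the 3 values shown sit. For compound 4 the estimate in this assay is 8000 nM, with a range from 3000 nM to 30000 nM, and a reported limit rather than a number is the likelier outcome.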

Compound 4, half-maximal inhibitory concentration: > 5000 nM
Compound 4: only a limit was reported; the forecaster's own chance of this, stated with the estimate: 80%; the middle value lies beyond the limit too.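

In this assay compound 4 gives > 5000 nM, a limit of the assay and not a number. No step can be read from compound 3 to compound 4, because the values of both compounds are limits: the limit of > 5000 nM in this assay, at which 4 of the 4 values shown sit. The compounds shown leave open whether 2H-tetrazol-5-yl in place of carboxy shifts inhibition at all on either core, and what actual value any of the four compounds has.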